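A few compounds are considered here, and "the series" means these few. Any claim that something is new, unique, unknown or untested is made for them only; others in the source may bear on it.

Measured so far in a functional assay on HEp-2 cells (Homo sapiens) for cytotoxicity; a lower number here means a stronger inhibitor, a higher number a weaker inhibitor:
Compound 1 `CSc1nc(N)c2nnn(C3O[C@H](CO)[C@@H](O)[C@H]3O)c2n1`: compound 1 gives a limit, > 130000 nM.
Compound 2 `CS(=O)(=O)c1nc(N)c2nnn(C3O[C@H](CO)[C@@H](O)[C@H]3O)c2n1`: compound 2 gives 14000 nM.
Compound 3 `CSc1nc(N)c2nn(C3O[C@H](CO)[C@@H](O)[C@H]3O)nc2n1`: compound 3 gives 25000 nM.

For the measured compounds named here, the one step measured is methylsulfonyl in place of methylsulfanyl on an aromatic carbon, which gives an at least 9.2-fold lower number from compound 1 to compound 2 (0.96 log units; beyond the scatter). Its size is a lower bound only, since compound 1 sits at the limit of > 130000 nM in this assay, at which 1 of the 3 values shown sits. Compound 3 carries the same methylsulfanyl group on a core that differs from that of compound 1; the difference between the two cores is not broken down here. Compound 3 and compound 2 lie within the scatter of each other.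

Compound 4 `CS(=O)(=O)c1nc(N)c2nn(C3O[C@H](CO)[C@@H](O)[C@H]3O)nc2n1` is not yet measured. It relates to compound 3 as compound 2 does to compound 1: methylsulfonyl in place of methylsulfanyl on an aromatic carbon. The place of the change is the same in both pairs, so this is the same change on a different core. On that basis the step from compound 3 to compound 4 is expected to go the same way, though whether its size repeats rests on a single bounded step and cannot be read from two cores; the estimate is a 3.1-fold lower number from compound 3 to compound 4 (0.49 log units; beyond the scatter). For compound 4 in this assay the expected value is 8000 nM, with a likely range of 2000 nM to 30000 nM.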

Compound 4, half-maximal inhibitory concentration: 22000 nM
Compound 4: middle estimate off by 2.8-fold (0.44 log units), on the low side, within the range that was stated.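

In this assay, methylsulfonyl in place of methylsulfanyl on an aromatic carbon does not carry its size from one core to the other: the same change on two cores in this assay, an at least 9.2-fold lower number (0.96 log units; beyond the scatter) from compound 1 to compound 2 and a 1.1-fold lower number (0.06 log units; within the scatter) from compound 3 to compound 4, at least 8.1-fold (0.91 log units) apart, beyond the scatter of two such steps

On the core of compound 3, the change amounts to a 1.1-fold lower number from compound 3 to compound 4 (0.06 log units; within the scatter), so the step on the core of compound 1 is no guide to its size here; these two pairs do not show why the cores part, or how the change would run on any further core. The step on the core of compound 1 has a lower bound only as its size, as compound 1 stands at a limit of the assay: the limit of > 130000 nM in this assay, at which 1 of the 4 values shown sits.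

Open, from the compounds shown here alone, is how each core responds when a different group takes that aromatic carbon, such as an amine, a methoxy group or a longer alkylsulfanyl chain. Also open, going by these compounds, is whether the gap between the two steps persists when the amino group or the sugar hydroxyl groups are changed.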